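This account rests on a few compounds, and the source may have more. Where it says the series, first, only, none or still open, it means among the compounds named here.

Working notes on the series. Three compounds have entries so far in a functional assay on MDA-MB-231 cells (Homo sapiens) for inhibition, read by MTT assay, with a stated time of 72 h; on this read-out lower numbers stand for stronger inhibition and higher numbers for weaker inhibition. Compound 1 `CCc1nc2c(C)cc(-c3ccc(CN4CCC[C@H]4CO)cc3)cn2c1NC(=O)OCc1cc(Cl)cc(Cl)c1` gives "nd" (no result reported), and compound 2 `CCc1nc2c(C)cc(-c3ccc(CN4CCN(C)CC4)cc3)cn2c1NC(=O)OCc1cc(Cl)cc(Cl)c1` gives "nd" (no result reported), so neither offers a number for comparison. Compound 3 `CCc1nc2c(C)cc(-c3ccc(CN4CCN(C)CC4)cc3)cn2c1NC(=O)OCc1ccc(C(F)(F)F)cc1` gives 4310 nM. For the measured compounds named here, this is the only number available, so compound 3 cannot yet be ranked against any other compound in this assay.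

Compound 4 `CCc1nc2c(C)cc(-c3ccc(CN4CCN(C)CC4)cc3)cn2c1NC(=O)OCc1ccc(F)c(F)c1` is the next one to be read in this assay. It keeps the rest of compound 3 and changes one group: 3,4-difluorophenyl in place of 4-(trifluoromethyl)phenyl on a saturated chain carbon bound to an oxygen next to a carbonyl group. Here 3,4-difluorophenyl takes the place of 4-(trifluoromethyl)phenyl on a saturated chain carbon bound to an oxygen next to a carbonyl group.

Going by the values given here, no measured pair shows what a change at this place does, so the data give no direction for it. With compound 3 at 4310 nM as the sole anchor, no shift beyond the usual scatter is expected. The expected size of the change is a 1.0-fold higher number from compound 3 to compound 4 (0.02 log units; within the scatter), an estimate that stays within that scatter. For compound 4 the estimated value is 4500 nM, with an expected range from 1700 nM to 12000 nM.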

Compound 4, half-maximal inhibitory concentration: 6230 nM
Compound 4: the middle estimate sits 1.4-fold (0.14 log units) below what was measured, and the stated range covers the measured number.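

In this assay, for the compounds shown here, 3,4-difluorophenyl in place of 4-(trifluoromethyl)phenyl on a saturated chain carbon bound to an oxygen next to a carbonyl group gives a 1.4-fold higher number from compound 3 to compound 4 (0.16 log units; within the scatter), which is the first step that can be read at this place. The two compounds therefore cannot be told apart in this read-out, even though the entering group has fewer heavy atoms than the leaving group, so this one exchange between two fluorine-bearing phenyl groups gives no direction for the place. No measured evidence bears on this result.

Compound 1 and compound 2 carry no number, so any step involving them cannot be read, and a single pair within the scatter does not show whether the place is tolerant in general or merely unchanged by this particular exchange. Going by these compounds, it remains open whether a group of another kind here, such as a phenyl carrying an amine or a carboxylic acid, or a longer chain ahead of the phenyl ring, would give a step beyond the scatter.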